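This account rests on a few compounds, and the source may have more. Where it says the series, first, only, none or still open, it means among the compounds named here.

Compound 1 `Cc1cc(-c2cccs2)cn2c(CSCCc3ccccc3)cnc12` carries a thiophen-2-yl group on its core, and in an ADME assay on HEL cells (Homo sapiens) for cytotoxicity, with a stated time of 3 days (a lower number here means that less compound is tolerated, a higher number that more compound is tolerated), compound 1 gives 20 ug/mL. Compound 2 `Cc1cc(-c2ccccc2)c2ncc(CSCCc3ccccc3)n2c1` is a close relative built on the same core with a phenyl group in another arrangement; in this assay compound 2 gives 20 ug/mL. Compound 1 stands level with compound 2 at the digits shown: the two values sit within the scatter of each other, so no order between them can be read from these numbers. Compound 3 `Cc1cc(-c2ccccc2O)cn2c(CSCCc3ccccc3)cnc12` has not yet been measured. It differs from compound 1 in one place: 2-hydroxyphenyl in place of thiophen-2-yl on an aromatic carbon. For the measured compounds named here, no pair of measured compounds shows what a swap of one aromatic group for another at this position does, so there is no measured step to lean on. Going by the values given here, the only guide is that the two measured compounds, though they carry different aromatic groups, give the same reading. On that basis the step of no change at the digits printed from compound 1 to compound 3 (within the scatter) is expected to be small, not beyond the scatter. Compound 3 is therefore estimated at 20 ug/mL in this assay, with a range from 8 ug/mL to 60 ug/mL.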

Compound 3, minimum cytotoxic concentration: 100 ug/mL
The estimate for compound 3 lay 5.0-fold (0.70 log units) below the measured number; measured number above the stated range.
By their numbers in this assay, from the lowest: compounds 1 and 2 (each within the scatter of the next); then compound 3.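

In this assay this aromatic carbon proves not to be indifferent to what it carries: 2-hydroxyphenyl in place of thiophen-2-yl gives a 5.0-fold higher number from compound 1 to compound 3 (0.70 log units; beyond the scatter) and thus a compound that the cells tolerate at a higher concentration. For the compounds shown here, no earlier pair offered a step at this position, and this first one shows that the choice of aromatic group here can move the reading beyond the scatter. The swap replaces a five-membered aromatic ring containing sulfur with a six-membered aromatic ring of carbon only and also brings in a hydrogen-bond donor, but these differences arrive together in one step and nothing measured here explains the rise.

Whether the hydroxy group or the six-membered ring accounts for the step stays open, as an unsubstituted phenyl group on this same carbon is not among the compounds shown. Also open, from the compounds shown here alone, is how a methoxy group in place of the hydroxy group, or an amine or a carboxylic acid on the same ring, would read in this assay.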